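Adding a Methyl Group: From Compound 2 to Compound 4

A few compounds are considered here, and "the series" means these few. Any claim that something is new, unique, unknown or untested is made for them only; others in the source may bear on it.

The compounds here share one core and differ in the group attached to it. Compound 1 `O=C(Cn1cc(COc2ccc3c(c2)CCC3)nn1)Nc1ccc(Br)cc1` carries a bromophenyl amide chain, compound 2 `Cc1ccc(-n2cc(COc3ccc4c(c3)CCC4)nn2)cc1` a 4-methylphenyl group, and compound 3 `Cc1ccc([N+](=O)[O-])cc1-n1cc(COc2ccc3c(c2)CCC3)nn1` a methylphenyl group bearing a nitro group. For the measured compounds named here, all three were set up for an ADME assay on HEK293 cells (Homo sapiens) for inhibition, read by MTT assay, with a stated time of 48 h, tested at 25 uM (on this read-out higher numbers stand for more inhibition at the one concentration tested (going by the name of the read-out) and lower numbers for less inhibition), yet only one gave a number: in this assay compound 3 gives 26.5%, a modest degree of inhibition at the single concentration tested. In this assay compound 1 is recorded as "not determined" (no result reported), and in the same assay compound 2 is recorded as "not determined" (no result reported), so compound 2 stands without a value of its own, and compound 1 is in the same position.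

The step now followed goes from compound 2 to compound 4 `Cc1ccc(-n2cc(COc3ccc4c(c3)CCC4)nn2)c(C)c1`, which adds a single group: methyl in place of hydrogen on an aromatic carbon. Going by the values given here, since no measured pair shows the effect of such a change, and the only number at hand is the low reading of compound 3, the step in this assay is expected to be small, with no clear direction beyond the usual scatter. On that basis compound 4 is estimated at 20%, within a range from 5% to 40%.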

Compound 4, a percentage reported as inhibition, at one concentration (the size of the read-out at that concentration, not a potency): 19.9%
Compound 4: the middle estimate sits 0.1 percentage points above what was measured, and the stated range covers the measured number.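

No step can be read from compound 2 to compound 4: in this assay compound 2 has no number of its own to set against compound 4. The compounds shown leave open whether this added methyl group raises, lowers or leaves unchanged the inhibition. No further data here bear on this result.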